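The source may report more compounds than this note shows. Statements on the series, on what has been measured and on what is new or still open speak of the compounds shown alone.

Compound 1 `CCCCc1cnc(C(CCC)Cc2ccc(-c3ccccc3C(=O)O)cc2)[nH]1` and compound 2 `COc1cccc(Cc2cnc(CCc3ccc(-c4ccccc4C(=O)O)cc3)[nH]2)c1` share a core and differ in the substituent on it. In an in vitro functional assay on cells for agonist activity at Bombesin receptor subtype-3 (Homo sapiens), read by luminescence and calcium flux (a lower number here means that less compound is needed, a higher number that more compound is needed for the effect), compound 1 gives 1180 nM, while compound 2 gives 4120 nM, the higher of the two numbers and beyond the scatter from compound 1. Compound 3 `O=C(O)c1ccccc1-c1ccc(CCc2ncc(CCC3CCCCC3)[nH]2)cc1` is the next step from compound 2: cyclohexylmethyl in place of 3-methoxyphenyl on a saturated chain carbon bound to an aromatic carbon. Among the measured compounds shown here, with no measured step of this kind to lean on, compound 1 with its aliphatic chain gives 1180 nM and suggests at most a modest move toward lower numbers, possibly within the scatter. Compound 3 is estimated at 2500 nM, range 900 nM to 7000 nM, a step of a 1.6-fold lower number from compound 2 to compound 3 (0.22 log units; within the scatter) expected.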

Compound 3, half-maximal effective concentration: 642 nM
For compound 3 the middle estimate is 3.9-fold (0.59 log units) above the measured one, outside the stated range (below it).
By their numbers in this assay, from the lowest: compounds 3 and 1 (each within the scatter of the next); then compound 2.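

Cyclohexylmethyl in place of 3-methoxyphenyl on a saturated chain carbon bound to an aromatic carbon gives a 6.4-fold lower number from compound 2 to compound 3 (0.81 log units; beyond the scatter) in this assay and so shows that this position responds to its substituent. An aromatic ring and a methoxy oxygen are not needed here for the lower number. Nothing measured on these compounds accounts for the step.
On these data alone, the step changes ring type, methoxy and chain length at once, so their shares stay open. A 2-phenylethyl group would separate ring type from chain length.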